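A Fluorophenyl Swap on the Shared Core of Compound 1

A few compounds are considered here, and "the series" means these few. Any claim that something is new, unique, unknown or untested is made for them only; others in the source may bear on it.

Compound 1 `Cc1ccc(-c2nc(N)c3cc(Cc4ccccc4)sc3n2)o1` was tested in a functional assay on CHO-K1 cells for antagonist activity at adenosine receptor A1 (Homo sapiens), read by a beta-galactosidase reporter and cAMP accumulation, with stated times of 15 min and 6 h (a lower number here means a stronger inhibitor, a higher number a weaker inhibitor), where compound 1 gives 298 nM. Among the three compounds measured, compound 1 stands second highest: its nearest neighbour is compound 3 `Cc1ccc(-c2nc(N)c3cc(C(C)c4ccccc4)sc3n2)o1`, which gives 439 nM, and the furthest is compound 2 `COc1ccccc1Cc1cc2c(N)nc(-c3ccc(C)o3)nc2s1`, which gives 122 nM. The step of a 2.4-fold lower number from compound 1 to compound 2 (0.39 log units; beyond the scatter) is modest but beyond the scatter, while the step of a 1.5-fold higher number from compound 1 to compound 3 (0.17 log units; within the scatter) lies within it. Both of these steps concern the arm bearing the benzene ring on the shared core.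

Compound 4 `Nc1nc(-c2cccc(F)c2)nc2sc(Cc3ccccc3)cc12` differs from compound 1 elsewhere: 3-fluorophenyl in place of 5-methylfuran-2-yl on an aromatic carbon. Among the measured compounds shown here, the group that leaves and the group that enters sit on the aromatic carbon between two ring nitrogen atoms, a position that none of the measured steps touches. The data therefore offer no measured change that bears directly on this exchange; the two steps recorded speak only to the other arm of the core. In the absence of any guide at this position, compound 4 is expected to show a step of a 1.2-fold higher number from compound 1 to compound 4 (0.07 log units; within the scatter), that is, nothing clearly beyond the scatter in either direction. The estimate for compound 4 in this assay is 350 nM, within a range from 110 nM to 1100 nM.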

Compound 4, inhibition constant: 123 nM
The estimate for compound 4 lay 2.8-fold (0.45 log units) above the measured number, and the stated range covers the measured number.
By their numbers in this assay, from the lowest: compounds 2 and 4 (each within the scatter of the next); then compounds 1 and 3 (each within the scatter of the next).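

In this assay, among the compounds shown here, the exchange gives a 2.4-fold lower number from compound 1 to compound 4 (0.38 log units; beyond the scatter), the only measured change on the aromatic carbon between two ring nitrogen atoms, and it shows that the number depends on the group at this position as well as on the arm bearing the benzene ring, the only part that the earlier steps touched. It also shows that the 5-methylfuran-2-yl group, a five-membered aromatic ring with 1 hydrogen-bond acceptor, is not required here for a number at the level of compound 1, as the 3-fluorophenyl group, a six-membered aromatic ring of carbon only with 0 hydrogen-bond acceptors, gives a lower one. Nothing at hand explains this modest step.

The compounds shown do not separate the contribution of the fluorine from that of the six-membered ring, a question that a plain phenyl or a pyridine ring at this carbon would address. They also leave open whether the methoxy group of compound 2 and the 3-fluorophenyl group of compound 4 would add up when carried together on the shared core.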